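The compounds below may be only part of what the source reports. "The series", "measured", "known", "first", "only" and "open" are said of these compounds alone.

Compound 1 `O=C(O)[C@@H]1CCCN1C(=O)/C=C/c1ccncc1-c1ccc2ccccc2c1` has no single number in an assay on a protein complex for inhibition of CDK8/Cyclin C (Homo sapiens), with a stated time of 1 h; a lower number here means a stronger inhibitor, a higher number a weaker inhibitor; the result reported for compound 1 there is "not determined" (no result reported). A related compound, compound 2 `O=C(/C=C/c1ccncc1-c1ccc2[nH]ccc2c1)N1CCOCC1`, gives 190 nM in this assay. Compound 3 `CCOC(=O)/C=C/c1ccncc1-c1ccc2ccccc2c1` differs from compound 1 by one change: ethoxy in place of 2-carboxypyrrolidin-1-yl on a carbonyl carbon. Going by the values given here, no step between measured compounds is available to guide the size of this change, so the expectation rests on compound 2 alone. For compound 3 a modest weakening relative to compound 2 is expected, though it may also come out no different beyond the usual scatter. Compound 3 is expected to give about 500 nM in this assay, with a range from 100 nM to 3000 nM.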

Compound 3, half-maximal inhibitory concentration: 53.3 nM
Compound 3: middle estimate off by 9.4-fold (0.97 log units), on the high side, and the stated range ends above it.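

Compound 1 has no number to set against compound 3, so no step can be read from this pair. How ethoxy compares with 2-carboxypyrrolidin-1-yl in this assay stays open, and nothing shown here accounts for the result for compound 3.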